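The source may hold more compounds than are shown below. What is called first, only, known or untested is meant among the compounds shown, and "the series" means these compounds.

Compound 1 `Cc1cn([C@@H]2O[C@H](CO[Si](C)(C)C(C)(C)C)[C@@]3(OS(=O)(=O)C=C3NCC(=O)C(=O)N3CCC3)[C@H]2O[Si](C)(C)C(C)(C)C)c(=O)n(C)c1=O` gives 21600 nM. Compound 2 `CCOC(=O)NC(=O)NC1=CS(=O)(=O)O[C@@]12[C@@H](CO[Si](C)(C)C(C)(C)C)O[C@@H](n1cc(C)c(=O)n(C)c1=O)[C@@H]2O[Si](C)(C)C(C)(C)C` gives 3000 nM. Compound 3 `COC(=O)CNC1=CS(=O)(=O)O[C@@]12[C@@H](CO[Si](C)(C)C(C)(C)C)O[C@@H](n1cc(C)c(=O)n(C)c1=O)[C@@H]2O[Si](C)(C)C(C)(C)C` gives 96000 nM.

In a functional assay on CCRF-CEM cells (Homo sapiens) (a lower number here means that less compound is tolerated, a higher number that more compound is tolerated), compound 3 stands highest of the three. Compound 4 `Cc1cn([C@@H]2O[C@H](CO[Si](C)(C)C(C)(C)C)[C@@]3(OS(=O)(=O)C=C3NC(N)=O)[C@H]2O[Si](C)(C)C(C)(C)C)c(=O)n(C)c1=O` differs from compound 3 in one place: carbamoyl in place of (methoxycarbonyl)methyl on an amine nitrogen. For the measured compounds named here, no measured step makes exactly this change. The closest comparison is with compound 2, which also carries a carbamoyl on that nitrogen, extended by an ethoxycarbonyl: a 32-fold higher number from compound 2 to compound 3 (1.51 log units; beyond the scatter). Likewise a 7.2-fold lower number from compound 1 to compound 2 (0.86 log units; beyond the scatter) shows the carbamoyl-bearing compound giving the lower number. A smaller downward step is therefore expected for compound 4, which lacks the ethoxycarbonyl part, the expected step being a 6.4-fold lower number from compound 3 to compound 4 (0.81 log units; beyond the scatter). Compound 4 is estimated at 15000 nM, within 3000 nM to 70000 nM.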

Compound 4, half-maximal cytotoxic concentration: 4360 nM
Compound 4: middle estimate off by 3.4-fold (0.54 log units), on the high side, and the stated range covers the measured number.
By their numbers in this assay, from the lowest: compounds 2 and 4 (each within the scatter of the next); then compound 1; then compound 3.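

In this assay carbamoyl in place of (methoxycarbonyl)methyl on the amine nitrogen brings a 22-fold lower number from compound 3 to compound 4 (1.34 log units; beyond the scatter) and so shows that the plain ureido group is enough for a low number. The ethoxycarbonyl extension of compound 2 makes no difference beyond the scatter, as a 1.5-fold higher number from compound 2 to compound 4 (0.16 log units; within the scatter) shows, while the side chain of compound 1 stands apart from the ureido group, with a 5.0-fold lower number from compound 1 to compound 4 (0.69 log units; beyond the scatter) as the step. No supporting measurement explains these differences. Left open is where a free carboxylic acid in place of the methyl ester would fall, and where a simple acetyl group on this nitrogen would fall.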